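The source may hold more compounds than are shown below. What is called first, only, known or untested is meant among the compounds shown, and "the series" means these compounds.

Compound 1 `N=c1sc2cc(OC(F)(F)F)ccc2n1CC(=O)O` in a functional assay on the whole organism with Rattus norvegicus as the target (on this read-out higher numbers stand for an effect only at larger amounts of compound and lower numbers for an effect already at smaller amounts), gives only a limit, > 10 mg/kg, the same limit recorded as the limit of > 10 mg/kg in this assay, at which 1 of the 3 values shown sits. Compound 2 `N=c1sc2cc(OC(F)(F)F)ccc2n1CC(N)=O` gives 7 mg/kg in this assay. Compound 3 `N=c1sc2cc(OC(F)(F)F)ccc2n1CCS(N)(=O)=O` gives 6 mg/kg in this assay, the lowest of the two numbers, with compound 2 nearest at a gap within the scatter, as a 1.2-fold lower number from compound 2 to compound 3 (0.07 log units; within the scatter) shows. The step of an at least 1.4-fold lower number from compound 1 to compound 2 (0.15 log units; that floor lies within the scatter) and the step of an at least 1.6-fold lower number from compound 1 to compound 3 (0.22 log units; that floor lies within the scatter) each have a floor that also lies within the scatter. Compound 4 `C[S+]([O-])CCn1c(=N)sc2cc(OC(F)(F)F)ccc21` has not been measured in this assay. It differs from compound 3 by a group of 3 heavy atoms (1 carbon, 1 oxygen, 1 sulfur; no ring) in place of a group of 4 heavy atoms (1 nitrogen, 2 oxygen, 1 sulfur; no ring), on a saturated chain carbon, two bonds along the chain from an aromatic nitrogen. The measured steps that bear on this are the exchange at the same place recorded as a 1.2-fold lower number from compound 2 to compound 3 (0.07 log units; within the scatter), which stayed within the scatter, and the floor of an at least 1.6-fold lower number from compound 1 to compound 3 (0.22 log units; that floor lies within the scatter), likewise within it. Both exchanges at that place left the read-out unmoved beyond the scatter, so no step beyond the scatter is expected in this assay in either direction. The expected step is therefore no change at the digits printed from compound 3 to compound 4 (within the scatter). Compound 4 is estimated at 6 mg/kg in this assay, with a range from 3 mg/kg to 12 mg/kg.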

Compound 4, dose for half-maximal effect: 1.1 mg/kg
Beside the measured number, compound 4's estimate is 5.5-fold (0.74 log units) above it; the whole stated range lies above it.
By their numbers in this assay, from the lowest: compound 4; then compounds 3 and 2 (each within the scatter of the next). At a limit, above all of these: compound 1.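

In this assay, going by these compounds alone, the place on a saturated chain carbon, two bonds along the chain from an aromatic nitrogen, proves sensitive to exchange after all: replacing sulfamoyl with the group of compound 4 gives a 5.5-fold lower number from compound 3 to compound 4 (0.74 log units; beyond the scatter), whereas the earlier steps among compounds 1, 2 and 3 stayed within the scatter or had floors within it. The group of compound 4 also stands clear of the shorter side chains, with a 6.4-fold lower number from compound 2 to compound 4 (0.80 log units; beyond the scatter) and an at least 9.0-fold lower number from compound 1 to compound 4 (0.95 log units; beyond the scatter), the second of these being only a floor. Nothing measured here gives a reason for these steps.

The entering group has 0 hydrogen-bond donors where sulfamoyl has 1 hydrogen-bond donor, but it also differs in its atoms, so this one exchange cannot tell which difference goes with the lower number. A methylsulfonyl group, a simple thioether or a longer chain carrying the same group would help to show whether the lower number depends on the oxidation level at sulfur, on the group on sulfur or on the length of the chain.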